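Swapping the amide amine toward a methyl(phenyl) group

The compounds below may be only part of what the source reports. "The series", "measured", "known", "first", "only" and "open" are said of these compounds alone.

Compound 1 `CCCCCN(CCCCC)C(=O)Cc1c(-c2ccc(OC)cc2)nn2c(CC)cc(CC)nc12` gives 2.17 nM in an assay on C6 cells for displacement of a labelled ligand from Translocator protein (Rattus norvegicus), read by scintillation counting, with a stated time of 2 h; a lower number here means a stronger inhibitor, a higher number a weaker inhibitor. Compound 2 `CCc1cc(CC)n2nc(-c3ccc(OC)cc3)c(CC(=O)N(C(C)CC)C(C)CC)c2n1` gives 14.4 nM, the higher of the two numbers, after the step of a 6.6-fold higher number from compound 1 to compound 2 (0.82 log units; beyond the scatter). Compound 3 `CCc1cc(CC)n2nc(-c3ccc(OC)cc3)c(CC(=O)N(C)c3ccccc3)c2n1` differs from compound 2 by methyl(phenyl)amino in place of bis(sec-butyl)amino on a carbonyl carbon. Within the data shown here, only that one step at the amide nitrogen bears on this change; it was modest and went upward, so a further modest rise beyond the scatter is expected. Compound 3 is therefore estimated at 30 nM, between 8 nM and 120 nM, an expected step of a 2.1-fold higher number from compound 2 to compound 3 (0.32 log units; beyond the scatter).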

Compound 3, inhibition constant: 6.44 nM
The estimate for compound 3 lay 4.7-fold (0.67 log units) above the measured number; the measured number lies below the stated range.
By their numbers in this assay, from the lowest: compound 1; then compound 3; then compound 2.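

Methyl(phenyl)amino, the only group here with a six-membered aromatic ring, gives a 2.2-fold lower number from compound 2 to compound 3 (0.35 log units; beyond the scatter), so moving away from dipentylamino at this carbonyl carbon does not always push the number up. Dipentylamino still holds the lowest number, with a 3.0-fold higher number from compound 1 to compound 3 (0.47 log units; beyond the scatter), which leaves compound 3 in the middle of the three. Nothing available explains this order. Still open, going by these compounds, is whether ethyl(phenyl)amino, or a ring amine such as piperidine, in the same place would match compound 1 or fall further behind it.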